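Swapping a pyrazole for a sulfonamide on an indane core

A few compounds are considered here, and "the series" means these few. Any claim that something is new, unique, unknown or untested is made for them only; others in the source may bear on it.

Measured compounds:
Compound 1 `c1cc(-c2ccn[nH]2)c2c(c1)C(c1ncc[nH]1)CC2` gives 336 nM in a functional assay on CHO cells for agonist activity at Alpha-1D adrenergic receptor (Homo sapiens), read by FLIPR and calcium flux; a higher number here means that more compound is needed for the effect, a lower number that less compound is needed.
Compound 2 `CCS(=O)(=O)Nc1cccc(Cc2c[nH]cn2)c1` gives only a limit of the assay, > 10000 nM.
Compound 3 `CS(=O)(=O)Nc1c(Cl)ccc2c1CCCC2c1ncc[nH]1` likewise gives only a limit, > 10000 nM.

Among the three values shown, compound 1 holds the only true number; the other two sit at a limit of the assay. Evidence of such limits is the limit of > 10000 nM in this assay, at which 2 of the 3 values shown sit. Compound 4 `CCS(=O)(=O)Nc1cccc2c1CCC2c1ncc[nH]1` has not yet been measured in this assay. It differs from compound 1 in one place: (ethylsulfonyl)amino in place of 1H-pyrazol-5-yl on an aromatic carbon.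

Among the measured compounds shown here, no step between measured compounds has been computed here, so the expected size must be judged from the values themselves. Compound 2 carries the same (ethylsulfonyl)amino group but without the fused core and reaches only a limit. Compound 3 carries a related sulfonamide on a fused core and also reaches only a limit. On that basis compound 4 is expected to lose activity, with a step from compound 1 of a 15-fold higher number from compound 1 to compound 4 (1.17 log units; beyond the scatter), well beyond the scatter. The estimate for compound 4 is 5000 nM, within a range of 1000 nM to 20000 nM, with a real chance that only a limit is reported.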

Compound 4, half-maximal effective concentration: > 10000 nM
Compound 4: only a limit was reported (the forecaster's own chance of this, stated with the estimate: 50%); middle value at least 2.0-fold (0.30 log units) from the limit.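

Among the compounds shown here, compound 4 is the first compound here that can be compared with compound 1 at a single place, as compounds 2 and 3 differ from it in more than one. With the rest of the structure held constant, putting (ethylsulfonyl)amino in place of 1H-pyrazol-5-yl on this aromatic carbon gives an at least 29-fold higher number from compound 1 to compound 4 (1.47 log units; beyond the scatter), so this one change is enough to lose nearly all measurable agonist activity in this assay. The step gives only a minimum size, and the compounds at this limit cannot be ranked against each other: the limit of > 10000 nM in this assay, at which 3 of the 4 values shown sit.

As far as these compounds go, what remains open is whether compound 1's activity needs the 1H-pyrazol-5-yl itself or would survive with another ring at this position, such as a phenyl, an imidazole or a pyridine. It is also unclear whether a small non-ring group, such as an amine, an amide or a methoxy group, would behave like the pyrazole or like the (ethylsulfonyl)amino group.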